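This account rests on a few compounds, and the source may have more. Where it says the series, first, only, none or still open, it means among the compounds named here.

Measured in a functional assay on MCF7 cells (Homo sapiens) for antiproliferative activity, read by MTT assay, with a stated time of 48 h (a higher number here means a weaker inhibitor, a lower number a stronger inhibitor), so far
compound 1 `Cc1ccc2[nH]c(-c3cn(-c4ccccc4)nc3-c3ccc(Cl)cc3)nc2c1` gives 8230 nM
compound 2 `COc1ccc(-c2nn(-c3ccccc3)cc2-c2nc3cc(OC)ccc3[nH]2)cc1` gives 3130 nM

Compound 2 holds the lower of the two numbers, and its gap to compound 1 lies beyond the scatter. Compound 3 `COc1ccc(-c2nn(-c3ccccc3)cc2-c2nc3cc(C)ccc3[nH]2)cc1` has methyl in place of methoxy on an aromatic carbon in the fused system of two rings. Within the data shown here, no measured step isolates this change, so the range stays wide. In this assay a small step toward a higher number is expected, near the edge of the scatter. The expected step is a 1.4-fold higher number from compound 2 to compound 3 (0.16 log units; within the scatter). The estimate for compound 3 is 4500 nM, with an expected range of 1800 nM to 11000 nM.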

Compound 3, half-maximal inhibitory concentration: 6610 nM
Beside the measured number, compound 3's estimate is 1.5-fold (0.17 log units) below it; the measured number falls inside the stated range.
By their numbers in this assay, from the lowest: compound 2; then compounds 3 and 1 (each within the scatter of the next).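

Methyl in place of methoxy on an aromatic carbon of the fused system of two rings is the first single change readable in this assay, and it costs a modest step (a 2.1-fold higher number from compound 2 to compound 3 (0.32 log units; beyond the scatter)). Methoxy in place of chloro on the other aromatic ring, with that methyl held constant, does not separate from the scatter (a 1.2-fold lower number from compound 1 to compound 3 (0.10 log units; within the scatter)). No measurement bearing on the reason for either step is available.

Going by these compounds, how a hydroxyl or an amine on that carbon of the fused system would compare with methoxy remains open. Also open, on these data alone, is whether the methoxy-to-methyl step holds with chloro on the other ring.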